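The source may hold more compounds than are shown below. What is called first, only, known or untested is meant among the compounds shown, and "the series" means these compounds.

Working notes on the solubility series. Compound 1 `CNc1nc(NCCCN(C)C)c2sc(-c3ccc(C(F)(F)F)cc3)cc2n1` gives 177 ug/mL in a physicochemical assay for solubility, in phosphate buffer, at pH 6.5; a lower number here means a less soluble compound, a higher number a more soluble compound. Compound 2 `CNc1nc(N)c2sc(-c3ccc(C(F)(F)F)cc3)cc2n1` gives 3.1 ug/mL in this assay. Compound 3 `CNc1nc(NC2CC2)c2sc(-c3ccc(C(F)(F)F)cc3)cc2n1` returns only a limit in this assay, namely < 5 ug/mL. Compound 3 therefore stands at the floor of the numbers shown, and its order against compound 2 cannot be read: the step that the limit leaves unreadable from compound 2 to compound 3 stays unreadable because of the limit of < 5 ug/mL in this assay, at which 1 of the 3 values shown sits. The two readable steps are a 57-fold lower number from compound 1 to compound 2 (1.76 log units; beyond the scatter) and an at least 35-fold lower number from compound 1 to compound 3 (1.54 log units; beyond the scatter), both large, both beyond the scatter, both downward once the 3-(dimethylamino)propyl leaves the nitrogen on the aromatic ring.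

Compound 4 `CNc1nc(Nc2cccc(S(C)(=O)=O)c2)c2sc(-c3ccc(C(F)(F)F)cc3)cc2n1` is not yet measured. It differs from compound 3 by 3-(methylsulfonyl)phenyl in place of cyclopropyl on a nitrogen on an aromatic ring. Among the measured compounds shown here, the only measured step that exchanges one group for another on that nitrogen without the 3-(dimethylamino)propyl is the unreadable one from compound 2 to compound 3, so no size can be read across for this change. Compound 4 is thus expected to remain near the floor, with the step that the limit leaves unreadable from compound 3 to compound 4 expected to be small or itself unreadable. In this assay compound 4 is expected at 3 ug/mL, within a range from 1 ug/mL to 12 ug/mL.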

Compound 4, solubility: < 5 ug/mL
Compound 4: a limit, no number; the forecaster's own chance of this, stated with the estimate: 55%; the middle value is on the limit's open side.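

In this assay compound 4 returns only a limit, < 5 ug/mL, and no number. Even so, a second replacement of the 3-(dimethylamino)propyl on this nitrogen on an aromatic ring gives a readable result, an at least 35-fold lower number from compound 1 to compound 4 (1.54 log units; beyond the scatter). Among the compounds shown here, the entering 3-(methylsulfonyl)phenyl brings a six-membered aromatic ring and 2 hydrogen-bond acceptors, which the cyclopropyl of compound 3 lacks, yet this large step has the same printed size as the one to compound 3, and that size is set by the limit. The steps that link compound 4 to compound 2 and compound 3 cannot be read, and the order among these compounds stays unknown: the limit of < 5 ug/mL in this assay, at which 2 of the 4 values shown sit.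

Among the compounds shown, only compound 1 carries a 3-(dimethylamino)propyl, so the series does not separate the role of its terminal dimethylamino group from that of its propyl chain. A morpholine at the end of the same chain, a shorter chain ending in an amine, or a carboxylic acid on the phenyl would each test that separately on the shared core.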